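Compound 2 and the step to compound 3

The compounds below may be only part of what the source reports. "The series", "measured", "known", "first", "only" and "open" are said of these compounds alone.

In a functional assay on MDA-MB-435 cells (Homo sapiens) for inhibition, read by sulforhodamine B assay, with a stated time of 48 h (on this read-out lower numbers stand for stronger inhibition of growth and higher numbers for weaker inhibition of growth), compound 1 `CN1CCCN(CCNc2nccc(-c3c(-c4cccc(O)c4)nc4sccn34)n2)S1(=O)=O` gives 51600 nM, and compound 2 `O=S(=O)(NCCCNc1nccc(-c2c(-c3cccc(O)c3)nc3sccn23)n1)c1cccc(F)c1` gives 6510 nM, the lower of the two numbers. Compound 3 `O=S(=O)(NCCNc1nccc(-c2c(-c3cccc(O)c3)nc3sccn23)n1)c1ccc(F)cc1` is still unmeasured. It differs from compound 2 as follows: ((4-fluorophenyl)sulfonyl)amino in place of (((3-fluorophenyl)sulfonyl)amino)methyl on a saturated chain carbon, two bonds along the chain from a nitrogen on an aromatic ring. In short, ((4-fluorophenyl)sulfonyl)amino stands in place of (((3-fluorophenyl)sulfonyl)amino)methyl.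

Among the compounds with values here, only one measured step bears on this change, a 7.9-fold lower number from compound 1 to compound 2 (0.90 log units; beyond the scatter), which replaced a non-aromatic ring group at the same place. Within the data shown here, compound 3 keeps the fluorine-bearing aromatic ring of compound 2, so that step offers no precedent for a change of similar size. A much smaller step is expected in this assay, probably none beyond the scatter and with no clear direction. The expected change is a 1.1-fold lower number from compound 2 to compound 3 (0.04 log units; within the scatter). For compound 3 the estimate is 6000 nM, with an expected range of 2500 nM to 15000 nM.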

Compound 3, concentration for total growth inhibition: 11600 nM
Beside the measured number, compound 3's estimate is 1.9-fold (0.29 log units) below it; the range from low to high includes it.
By their numbers in this assay, from the lowest: compounds 2 and 3 (each within the scatter of the next); then compound 1.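

In this assay, the swap at this position gives a 1.8-fold higher number from compound 2 to compound 3 (0.25 log units; within the scatter), so this change stays within the scatter even though the entering group lacks the methyl of the leaving group and carries its fluorine at a different ring position. The step of a 4.4-fold lower number from compound 1 to compound 3 (0.65 log units; beyond the scatter) is beyond the scatter, so both groups with a fluorine-bearing aromatic ring now stand apart from the non-aromatic ring group of compound 1. No measurement bears on what lies behind these numbers.

Going by these compounds, compound 2 and compound 3 differ in the methyl and in the fluorine position together, so the share of each remains open. Also open, on these data alone, is how an unsubstituted phenyl, a primary amine or a longer chain would read at this place in this assay.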